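The source may hold more compounds than are shown below. What is called first, only, known or untested is meant among the compounds shown, and "the series" means these compounds.

In a functional assay (trachea) with Cavia porcellus as the target (a lower number here means a stronger inhibitor, a higher number a weaker inhibitor), compound 1 `Oc1nnc(-c2cccnc2)c2ccccc12` gives 10200 nM while compound 2 `CCn1nc(-c2cccnc2)c2ccccc2c1=O` gives 1320 nM and compound 3 `C=CCn1nc(-c2cccnc2)c2ccccc2c1=O` gives 2140 nM as its reading. Compound 3 thus lies within the scatter of compound 2 and clearly under compound 1. Compound 4 `CC(=O)Cn1nc(-c2cccnc2)c2ccccc2c1=O` keeps the shared core and differs from compound 3 in one group, acetyl in place of vinyl on a saturated chain carbon bound to an aromatic nitrogen with acetyl in place of vinyl on a saturated chain carbon bound to an aromatic nitrogen. For the measured compounds named here, the only measured step at this place is a 1.6-fold higher number from compound 2 to compound 3 (0.21 log units; within the scatter) and it did not add a hydrogen-bond acceptor, so it is weak guidance. No step beyond the scatter is therefore expected in this assay in either direction. The estimated change is small, a 1.2-fold higher number from compound 3 to compound 4 (0.07 log units; within the scatter) at most a modest drift. Compound 4 is expected at about 2500 nM with an estimated range from 800 nM to 7500 nM.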

Compound 4, half-maximal inhibitory concentration: 40700 nM
Estimate against measurement, compound 4: 16-fold (1.21 log units) below, outside the stated range (above it).
By their numbers in this assay, from the lowest: compounds 2 and 3 (each within the scatter of the next); then compound 1; then compound 4.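

Acetyl in place of vinyl gives a 19-fold higher number from compound 3 to compound 4 (1.28 log units; beyond the scatter) in this assay and acetyl in place of methyl gives a 31-fold higher number from compound 2 to compound 4 (1.49 log units; beyond the scatter) on the same saturated chain carbon. This place therefore does not accept every small group alike, although vinyl in place of methyl stayed within the scatter. Unlike vinyl, the entering acetyl carries a hydrogen-bond acceptor, but no measurement here explains the large change. Still open, on these data alone, is whether the carbonyl itself matters. A 2-hydroxypropyl group, an amine or a longer plain carbon chain at this place could help separate its contribution from that of chain size.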